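Benzylsulfanyl variation on a dioxino-fused triazole series

This account rests on a few compounds, and the source may have more. Where it says the series, first, only, none or still open, it means among the compounds named here.

Measured so far:
- compound 1, `Sc1nnc(-c2ccc3c(c2)OCCO3)n1-c1ccccc1`: 38400 nM in a functional assay on SW 1116 cells (Homo sapiens) for antiproliferative activity, read by MTT assay, with a stated time of 24 h; a lower number here means a stronger inhibitor, a higher number a weaker inhibitor
- compound 2, `Clc1cccc(CSc2nnc(-c3ccc4c(c3)OCCO4)n2-c2ccccc2)c1`: 10600 nM in this assay

Within the data shown here, compound 2 carries the lower of the two numbers in this assay, and its only neighbour is compound 1; the step of a 3.6-fold lower number from compound 1 to compound 2 (0.56 log units; beyond the scatter), which corresponds to 3-chlorobenzyl in place of hydrogen on a sulfur, is beyond the scatter and sets compound 2 apart as the stronger inhibitor of the pair.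

Compound 3 is `Fc1ccc(CSc2nnc(-c3ccc4c(c3)OCCO4)n2-c2ccccc2)c(F)c1`, not yet measured in this assay. It differs from compound 2 as follows: 2,4-difluorophenyl in place of 3-chlorophenyl on a saturated chain carbon bound to a sulfur. Among the measured compounds shown here, no measured step touches this kind of change; the one step known, a 3.6-fold lower number from compound 1 to compound 2 (0.56 log units; beyond the scatter), concerns the presence of the whole benzyl group on the sulfur, not the substitution pattern of its ring. The data therefore give no direction for swapping 3-chlorophenyl for 2,4-difluorophenyl on the saturated chain carbon bound to the sulfur.

The expectation for compound 3 in this assay is a number close to that of compound 2, with the step of a 1.1-fold higher number from compound 2 to compound 3 (0.05 log units; within the scatter) expected to stay within the scatter. Compound 3 is estimated at 12000 nM, in the range 4000 nM to 36000 nM.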

Compound 3, half-maximal inhibitory concentration: 7830 nM
Beside the measured number, compound 3's estimate is 1.5-fold (0.19 log units) above it, within the range that was stated.
By their numbers in this assay, from the lowest: compounds 3 and 2 (each within the scatter of the next); then compound 1.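

In this assay, 2,4-difluorophenyl in place of 3-chlorophenyl on a saturated chain carbon bound to a sulfur gives a 1.4-fold lower number from compound 2 to compound 3 (0.13 log units; within the scatter), so the two substituted rings cannot be told apart at this position. Against the parent, putting the 2,4-difluorobenzyl group onto the sulfur gives a 4.9-fold lower number from compound 1 to compound 3 (0.69 log units; beyond the scatter), so the step beyond the scatter seen earlier with 3-chlorobenzyl is not confined to that one group: both benzyl compounds shown, compound 2 and compound 3, go the same way, and neither goes against it. No supporting measurement bears on this result.

The 3-chlorophenyl and 2,4-difluorophenyl rings differ in both the halogen and the number of halogen atoms, so the compounds shown cannot separate these two changes, and the part played by the halogens themselves remains unresolved. Also open, on these data alone, is whether the unsubstituted benzyl group, a longer chain between the sulfur and the ring, or a ring bearing an amine or a carboxylic acid would keep, lose or improve on the numbers of compound 2 and compound 3.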